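The source may report more compounds than this note shows. Statements on the series, on what has been measured and on what is new or still open speak of the compounds shown alone.

Measured so far:
Compound 1 `CC(Sc1nc2c(cnn2C)c(=O)n1-c1ccccc1)c1ccccn1` — 97%
Compound 2 `CC(Sc1nc2c(cnn2C)c(=O)n1-c1ccc(C#N)cc1)c1ccccc1` — "active" (no number reported)

In an assay on PEO1 cells for inhibition of Retinaldehyde dehydrogenase 3 (Homo sapiens), read by flow cytometry, with a stated time of 30 min, tested at 1 uM (on this read-out lower numbers stand for less inhibition and higher numbers for more inhibition at the one concentration tested (going by the name of the read-out)), compound 2 is reported only as "active" (no number reported) and so has no number to stand on; compound 1, which shares the core, gives 97% in this assay. Compound 3 `CC(Sc1nc2c(cnn2C)c(=O)n1-c1ccccc1)c1ccccc1` is not yet measured. From compound 2 to compound 3 the change is hydrogen in place of cyano on an aromatic carbon. Among the measured compounds shown here, no step between measured compounds is known for this change, so no size beyond the scatter is expected in either direction in this assay. Compound 3 is expected to give about 85% in this assay, within 55% to 100%.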

Compound 3, a percentage reported as inhibition, at one concentration (the size of the read-out at that concentration, not a potency): 47%
Compound 3: the middle estimate sits 38 percentage points above what was measured, outside the stated range (below it).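

In this assay, the group on the saturated chain carbon bound to a saturated chain carbon and a sulfur clearly matters: phenyl in place of pyridin-2-yl gives a number 50 percentage points lower from compound 1 to compound 3 (beyond the scatter). The 4-cyanophenyl to phenyl change cannot be read, as compound 2 has no number. Nothing at hand bears on the cause of this step. Still open, from the compounds shown here alone, is how other groups on that carbon, such as pyridin-3-yl or a morpholine, compare with pyridin-2-yl. Also open, going by these compounds, is whether pyridin-2-yl and 4-cyanophenyl can be combined in one compound.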